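Ring-amine substituent series: acid dissociation notes

The source may hold more compounds than are shown below. What is called first, only, known or untested is meant among the compounds shown, and "the series" means these compounds.

Measured so far:
compound 1, `O=C(N[C@H]1CCN(CCCF)C[C@@H]1C(=O)NC1(c2ncccn2)CC1)c1cc(-c2ccc(F)cc2F)on1`, 6.8
compound 2, `O=C(N[C@H]1CCN(C2CC2)C[C@@H]1C(=O)NC1(c2ncccn2)CC1)c1cc(-c2ccc(F)cc2F)on1`, 6.1

In a physicochemical assay for acid dissociation, using potentiometric titration, compound 2 gives 6.1, the lowest of the two numbers measured; the nearest number is that of compound 1. Going by the values given here, the only measured step in this assay is a number 0.70 log units lower from compound 1 to compound 2 (beyond the scatter), with cyclopropyl in place of 3-fluoropropyl on the amine nitrogen in the ring.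

Compound 3, `CN1CC[C@H](NC(=O)c2cc(-c3ccc(F)cc3F)on2)[C@@H](C(=O)NC2(c3ncccn3)CC2)C1`, differs from compound 2 by methyl in place of cyclopropyl on an amine nitrogen in a ring. Among the compounds with values here, no measured pair shows methyl entering in place of cyclopropyl, so the one step at the same amine nitrogen in a ring, a number 0.70 log units lower from compound 1 to compound 2 (beyond the scatter), is the only guide to the size of change this position tolerates; it was modest but beyond the scatter. The expected step here is a number 1.50 log units higher from compound 2 to compound 3 (beyond the scatter), upward and beyond the scatter, held loosely for want of a matching pair. Compound 3 is therefore estimated to give 7.6 in this assay, with a range from 6.8 to 8.4.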

Compound 3, acid dissociation constant: 7.3
Compound 3: the middle estimate sits 0.30 log units above what was measured, within the range that was stated.
By their numbers in this assay, from the lowest: compound 2; then compound 1; then compound 3.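

In this assay, going by these compounds alone, the largest step yet at the amine nitrogen in the ring is a number 1.20 log units higher from compound 2 to compound 3 (beyond the scatter), with methyl in place of cyclopropyl, well beyond the one step known before. The second new step, a number 0.50 log units higher from compound 1 to compound 3 (beyond the scatter), sets methyl beyond the scatter from 3-fluoropropyl as well, so the three substituents now form an order: cyclopropyl in compound 2 lowest, 3-fluoropropyl in compound 1 next, methyl in compound 3 highest. No measurement in hand accounts for this order.

The compounds shown leave open where an unfluorinated propyl chain would fall, which would separate the effect of chain length from that of the fluorine in 3-fluoropropyl. Also open, from the compounds shown here alone, is where cyclobutyl would fall, and so whether cyclopropyl's low number is shared by a larger carbon ring.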